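Lengthening the Ester Chain of a Malonamide ACAT Inhibitor

The source may report more compounds than this note shows. Statements on the series, on what has been measured and on what is new or still open speak of the compounds shown alone.

Measured so far:
compound 1 `CC(C)c1cccc(C(C)C)c1NC(=O)CC(=O)O`: > 5000 nM
compound 2 `CCOC(=O)CC(=O)Nc1c(C(C)C)cccc1C(C)C`: 1800 nM

Compound 1 `CC(C)c1cccc(C(C)C)c1NC(=O)CC(=O)O` gives > 5000 nM in an assay on microsomes from intestine for inhibition of acyl-CoA:cholesterol acyltransferase (Oryctolagus cuniculus) (a higher number here means a weaker inhibitor, a lower number a stronger inhibitor), which is a limit of the assay rather than a number (the limit of > 5000 nM in this assay, at which 1 of the 2 values shown sits). Compound 2 `CCOC(=O)CC(=O)Nc1c(C(C)C)cccc1C(C)C` gives 1800 nM in this assay; it is the only plain number shown. Among the compounds with values here, the one measured step, an at least 2.7-fold lower number from compound 1 to compound 2 (0.44 log units; beyond the scatter), consists of ethyl in place of hydrogen on an oxygen next to a carbonyl group.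

Compound 3 `CCCCCCCCCCC(C)OC(=O)CC(=O)Nc1c(C(C)C)cccc1C(C)C` is not yet measured. It differs from compound 2 by decyl in place of hydrogen on a saturated chain carbon bound to an oxygen next to a carbonyl group and a saturated chain carbon. Within the data shown here, the only step on hand bears on the same ester oxygen and was at least modest in the favourable direction, so a further gain of similar size, not more than modest, is expected. For compound 3 the estimate in this assay is 600 nM, within 150 nM to 3000 nM. The expected step is a 3.0-fold lower number from compound 2 to compound 3 (0.48 log units; beyond the scatter).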

Compound 3, half-maximal inhibitory concentration: 6 nM
Estimate against measurement, compound 3: 100-fold (2.00 log units) above; the whole stated range lies above it.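

With decyl on a saturated chain carbon bound to an oxygen next to a carbonyl group and a saturated chain carbon, the ester group turns out to matter far more than the first step suggested, giving a 300-fold lower number from compound 2 to compound 3 (2.48 log units; beyond the scatter) in this assay. Compound 2 had shown only that an ethyl ester does better than the free carboxylic acid, whereas this large step shows that the inhibitor's strength also depends heavily on what the ester carries. Compound 1 remains a limit of the assay, not a number: the limit of > 5000 nM in this assay, at which 1 of the 3 values shown sits.

On these data alone, with only one long chain in hand, it stays open whether a shorter chain such as butyl would give part of this gain. As far as these compounds go, it is equally open whether a longer chain, or an amine or a phenyl ring in place of the decyl, would keep it.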